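The source may report more compounds than this note shows. Statements on the series, on what has been measured and on what is new or still open speak of the compounds shown alone.

Measured compounds in a functional assay on K562 cells (Homo sapiens) for inhibition, read by MTT assay, with a stated time of 48 h; a lower number here means a stronger inhibitor, a higher number a weaker inhibitor:
- compound 1 `Cc1ccccc1-n1nc(C)c(C(=O)Nc2ccc3ccccc3n2)c1C` gives 3800 nM
- compound 2 `CCc1ccccc1-n1nc(C)c(C(=O)Nc2ccc3ccccc3n2)c1C` gives 900 nM

Among the compounds with values here, compound 2 has the lowest of the two numbers so far; its nearest neighbour is compound 1, and the only step between them is a 4.2-fold lower number from compound 1 to compound 2 (0.63 log units; beyond the scatter). Compound 3 `Cc1nn(-c2ccccc2Br)c(C)c1C(=O)Nc1ccc2ccccc2n1` has not yet been measured in this assay. It differs from compound 2 in one place: bromo in place of ethyl on an aromatic carbon, on an aromatic carbon of a six-membered aromatic ring of carbon only, ortho to a large group.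

Within the data shown here, no measured step involves a bromo group, so the change from compound 2 to compound 3 is not covered directly. Among the measured compounds shown here, the one step that bears on it at all is the step from compound 1 to compound 2, which changed the same position from methyl to ethyl and moved the number modestly. That step shows the position responds to what is placed there, but it gives no direction for a bromo in place of ethyl. A modest change is therefore expected for compound 3 in this assay, with a 1.7-fold higher number from compound 2 to compound 3 (0.22 log units; within the scatter) as the expected step and a wide range around it. The estimate for compound 3 is 1500 nM, between 500 nM and 5000 nM.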

Compound 3, half-maximal inhibitory concentration in the K562 assay: 3000 nM
Beside the measured number, compound 3's estimate is 2.0-fold (0.30 log units) below it; the range from low to high includes it.
By their numbers in the K562 assay, from the lowest: compound 2; then compounds 3 and 1 (each within the scatter of the next).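

In the K562 assay, bromo in place of ethyl gives a 3.3-fold higher number from compound 2 to compound 3 (0.52 log units; beyond the scatter), with compound 3 at 3000 nM, and so does not keep what ethyl brought at this place on the aromatic ring, which the earlier pair alone could not show. In the K562 assay, bromo in place of methyl gives a 1.3-fold lower number from compound 1 to compound 3 (0.10 log units; within the scatter) and leaves those two groups unseparated in this assay, so among the three groups shown here, only the ethyl of compound 2 stands apart from the others, and the response at this place does not simply follow the number of heavy atoms in the group, since bromo and methyl, each a single heavy atom, read alike while ethyl differs. In a physicochemical assay for solubility, read by HPLC, in phosphate buffer, with a stated time of 6 h, at pH 7.4 (on this read-out lower numbers stand for lower solubility and higher numbers for higher solubility), compound 2 gives 5.2 ug/mL and compound 3 gives 5.9 ug/mL, and the same exchange gives a 1.1-fold higher number from compound 2 to compound 3 (0.05 log units; within the scatter) and so shows no separation on this read-out. In the K562 assay, by contrast, the step between the same two compounds lies beyond the scatter.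

Nothing available explains why ethyl and bromo differ at this place. Still open, going by these compounds, is whether a longer chain such as propyl would carry the trend from methyl to ethyl further, and how a methoxy group or an amine at the same place would read against the ethyl of compound 2.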